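Naphthalene-sulfonamide endothelin antagonists: replacing the amine

A few compounds are considered here, and "the series" means these few. Any claim that something is new, unique, unknown or untested is made for them only; others in the source may bear on it.

Measured so far:
- compound 1 `CCCNc1ccc(S(=O)(=O)Nc2onc(C)c2C)cc1`: 27000 nM
- compound 2 `Cc1noc(NS(=O)(=O)c2cccc3c(NC(C)C)cccc23)c1C`: 20 nM
- compound 3 `Cc1noc(NS(=O)(=O)c2cccc3c(NCCCCCc4ccccc4)cccc23)c1C`: 3050 nM

In an assay on VSM-A10 cells for antagonist activity at Endothelin-1 receptor (Rattus norvegicus) (on this read-out higher numbers stand for weaker inhibition and lower numbers for stronger inhibition), compound 2 gives the lowest number of the three measured, with compound 3 nearest at 3050 nM and compound 1 furthest at 27000 nM. Among the compounds with values here, the one step that alters the group on the nitrogen, a 150-fold higher number from compound 2 to compound 3 (2.18 log units; beyond the scatter), is large, so this position is sensitive. Compound 4 `Cc1noc(NS(=O)(=O)c2cccc3c(C(C)(C)O)cccc23)c1C` changes compound 2 by 1-hydroxy-1-methylethyl in place of isopropylamino on an aromatic carbon. Within the data shown here, no measured step removes the nitrogen itself, so the bearing of the step from compound 2 to compound 3 is indirect. A moderate rise is expected, a 6.0-fold higher number from compound 2 to compound 4 (0.78 log units; beyond the scatter), with compound 4 estimated at 120 nM within 25 nM to 600 nM.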

Compound 4, half-maximal inhibitory concentration: 2890 nM
Estimate against measurement, compound 4: 24-fold (1.38 log units) below; the measured number lies above the stated range.
By their numbers in this assay, from the lowest: compound 2; then compounds 4 and 3 (each within the scatter of the next); then compound 1.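

Replacing isopropylamino with 1-hydroxy-1-methylethyl gives a 140-fold higher number from compound 2 to compound 4 (2.16 log units; beyond the scatter) even though the heavy-atom count, hydrogen-bond donor and acceptor counts, and lack of net charge stay the same, so matching these counts does not preserve the low number of compound 2. Sensitivity at this position is therefore not confined to changes in the group on the nitrogen: replacing the nitrogen itself also produces a large step. Nothing available explains this step.

From the compounds shown here alone, it remains open whether an isopropoxy or tert-butyl group would behave like isopropylamino or like 1-hydroxy-1-methylethyl. A smaller amine such as ethylamino would also show how much of the isopropyl group is needed.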